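This account rests on a few compounds, and the source may have more. Where it says the series, first, only, none or still open, it means among the compounds named here.

Of the compounds shown here, three built on a shared core have been measured in an assay on HEK293 cells for displacement of a labelled ligand from Sigma non-opioid intracellular receptor 1 (Homo sapiens), read by scintillation counting, with a stated time of 120 min; a lower number here means a stronger inhibitor, a higher number a weaker inhibitor. Compound 1 `CCOc1ccccc1-c1ncnc2c1cnn2CCN1CCCCC1` gives 300 nM. Compound 3 `FC(F)(F)c1ccccc1-c1ncnc2c1cnn2CCN1CCCCC1` gives 125 nM; the change from compound 1 to compound 3, trifluoromethyl in place of ethoxy on an aromatic carbon, brought a 2.4-fold lower number from compound 1 to compound 3 (0.38 log units; beyond the scatter). Compound 2 `Fc1cc(Cl)ccc1-c1ncnc2c1cnn2CCN1CCCCC1` gives 112 nM, the smallest of the three numbers, though the gap to compound 3 is within the scatter and only the gap to compound 1 lies beyond it. Compound 4 `Cn1cnc(-c2ncnc3c2cnn3CCN2CCCCC2)c1` has not yet been measured. It differs from compound 2 in this way: 1-methyl-1H-imidazol-4-yl in place of 4-chloro-2-fluorophenyl on an aromatic carbon. Among the measured compounds shown here, the single step measured so far altered a substituent on a six-membered aromatic ring of carbon only; no measured step replaces that ring with a five-membered aromatic ring with 2 hetero atoms, so nothing measured bears directly on the change to compound 4, and the expectation below is loosely held. Compound 4 is expected to give 1000 nM in this assay, with a range from 250 nM to 4000 nM. The expected step is an 8.9-fold higher number from compound 2 to compound 4 (0.95 log units; beyond the scatter).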

Compound 4, inhibition constant: 11800 nM
Compound 4: middle estimate off by 12-fold (1.07 log units), on the low side; the measured number lies above the stated range.
By their numbers in this assay, from the lowest: compounds 2 and 3 (each within the scatter of the next); then compound 1; then compound 4.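

In this assay, among the compounds shown here, 1-methyl-1H-imidazol-4-yl in place of 4-chloro-2-fluorophenyl brought a 110-fold higher number from compound 2 to compound 4 (2.02 log units; beyond the scatter) and so a far larger shift than the one earlier step, a 2.4-fold lower number from compound 1 to compound 3 (0.38 log units; beyond the scatter) on a substituent. The result shows that at this aromatic carbon the identity of the ring itself matters much more than that earlier substituent change, and that this position does not accept every aromatic ring equally. Nothing available explains the size of this step.

A single step changes ring size, hetero atoms and the methyl group together, so these cannot be told apart here. As far as these compounds go, whether a pyridine or a thiophene at this position would stay near compound 2, and whether an imidazole without the methyl group would differ from compound 4, remains open.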